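Taking one methoxy group from compound 2

The source may report more compounds than this note shows. Statements on the series, on what has been measured and on what is new or still open speak of the compounds shown alone.

Compound 1 `COc1cc(OC)c(OC)cc1/C=C/COC(=O)/C=C/c1ccc(OC)c(OC)c1` and compound 2 `COc1cc(OC)c(OC)cc1/C=C/COC(=O)/C=C/c1cc(OC)c(OC)c(OC)c1OC` share a core. In a functional assay on the whole organism (strain Kunming) with Mus musculus as the target, with a stated time of 0.5 h (a lower number here means that less compound is needed, a higher number that more compound is needed for the effect), compound 1 gives > 723 umol/kg as a limit of the assay and not a number. In this assay compound 2 gives > 421 umol/kg as a limit too, so compound 2 has no measured dose. Compound 3 `COc1cc(OC)c(OC)cc1/C=C/COC(=O)/C=C/c1cc(OC)c(OC)c(OC)c1` has hydrogen in place of methoxy on an aromatic carbon compared with compound 2. Among the compounds with values here, no measured step guides the size of the change, but a modest move to a lower dose is expected in this assay and the estimated change is an at least 1.4-fold lower number from compound 2 to compound 3 (0.14 log units; that floor lies within the scatter) with wide uncertainty. For compound 3 the estimate is 300 umol/kg with an expected range from 100 umol/kg to 800 umol/kg in this assay as the expected outcome.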

Compound 3, dose for half-maximal effect: > 450 umol/kg
Compound 3: only a limit was reported; the forecaster's own chance of this, stated with the estimate: 45%; middle value at least 1.5-fold (0.17 log units) from the limit.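

In this assay compound 3 gives > 450 umol/kg, a limit and not a number. With compound 1 and compound 2 also limits, no step among these compounds can be read. From the compounds shown here alone, whether removing a methoxy group changes the dose remains open.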